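Cytotoxicity notes on three measured compounds and one pending

The source may report more compounds than this note shows. Statements on the series, on what has been measured and on what is new or still open speak of the compounds shown alone.

Compound 1 `O=C(Nc1cccc(Oc2ccccn2)c1)C1CCCN(C(=O)c2cc(C(F)(F)F)cc(C(F)(F)F)c2)C1` in an ADME assay on PC-3 cells (Homo sapiens) for cytotoxicity, read by WST assay, tested at 100 uM (a higher number here means more inhibition at the concentration tested (going by the name of the read-out), a lower number less inhibition), gives 0%. Compound 2 `COC(=O)c1cccc(C(=O)N2CCCC(C(=O)Nc3ccc(Cl)cc3)C2)c1` gives 0% in this assay, and compound 3 `CSc1cccc(C(=O)N2CCCC(C(=O)Nc3ccc(Cl)cc3)C2)c1` gives 0%; the step of no change at the digits printed from compound 2 to compound 3 (within the scatter) stays within the scatter. Compound 1 stands level with compounds 2 and 3 at the digits shown, nearest to compound 2 and furthest from compound 3, both within the scatter.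

Compound 4 `COC(=O)c1cc(-c2cccc(NC(=O)C3CCCN(C(=O)c4cc(C(F)(F)F)cc(C(F)(F)F)c4)C3)c2)co1` has not yet been measured in this assay. It differs from compound 1 as follows: 5-(methoxycarbonyl)furan-3-yl in place of (pyridin-2-yl)oxy on an aromatic carbon. Going by the values given here, no measured step exchanges a group at this place or involves either of these two groups; the only measured step, no change at the digits printed from compound 2 to compound 3 (within the scatter), changes a group on a different aromatic carbon and does not move the read-out beyond the scatter. All measured values in this assay sit at one level, so for compound 4 the expected step is none beyond the scatter, no change at the digits printed from compound 1 to compound 4 (within the scatter). Compound 4 is estimated at 0% in this assay, with a range from 0% to 12%.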

Compound 4, a percentage reported as inhibition, at one concentration (the size of the read-out at that concentration, not a potency): 0%
For compound 4 middle estimate and measured number coincide at the digits printed; the range from low to high includes it.
By their numbers in this assay, from the lowest: compounds 1, 2, 3 and 4 (each within the scatter of the next).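

In this assay, 5-(methoxycarbonyl)furan-3-yl in place of (pyridin-2-yl)oxy gives no change at the digits printed from compound 1 to compound 4 (within the scatter) at this place, an aromatic carbon meta to a large group. Going by these compounds alone, the step reaches a position the earlier step did not touch, and it exchanges a six-membered aromatic ring for a five-membered one while the read-out stays at one level, so the insensitivity seen so far now covers two different aromatic carbons, though in only two steps. Nothing measured bears on why this read-out stays level across the change.

With all four compounds at one level, these data give no sign of which parts of the structure, if any, can move this read-out. Going by these compounds, it remains open whether a carboxylic acid in place of the methoxycarbonyl, or an amine at this place, would lift it off that level.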